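The source may report more compounds than this note shows. Statements on the series, on what has been measured and on what is new or still open speak of the compounds shown alone.

Measured so far:
- compound 1 `CC1=C(C(=O)NC(C)C)C(c2ccsc2)NC(=O)N1`: 8%
- compound 2 `CCC(CC)OC(=O)C1=C(C)NC(=O)NC1c1ccsc1`: 22%

In an assay on membranes from CHO cells for displacement of a labelled ligand from adenosine receptor A1 (Homo sapiens), read by scintillation counting, with a stated time of 60 min, tested at 1 uM (on this read-out higher numbers stand for more inhibition at the one concentration tested (going by the name of the read-out) and lower numbers for less inhibition), compound 1 gives 8% and compound 2 gives 22%. For the measured compounds named here, the one step measured so far is a number 14 percentage points higher from compound 1 to compound 2 (beyond the scatter), the exchange of isopropylamino for (pentan-3-yl)oxy on a carbonyl carbon. Going by the values given here, on the numbers in hand compound 2 stands highest of the two, with compound 1 as the only neighbour and that step separating them.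

Compound 3 `CC1=C(C(=O)OC2CCCCC2)C(c2ccsc2)NC(=O)N1` is the next member of the series and has not been measured. It differs from compound 2 by cyclohexyl in place of pentan-3-yl on an oxygen next to a carbonyl group. Among the compounds with values here, no measured step alters the group on that oxygen: the step from compound 1 to compound 2 replaces the whole isopropylamino by (pentan-3-yl)oxy and so speaks to the ester against the amide, not to one alkyl on the ester oxygen against another. The change from compound 2 to compound 3 keeps the ester and keeps a comparable alkyl on it, so the expectation for this assay is a step of a number 2 percentage points higher from compound 2 to compound 3 (within the scatter), within the scatter. The estimate for compound 3 in this assay is therefore 24%, with a range from 8% to 42%.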

Compound 3, a percentage reported as inhibition, at one concentration (the size of the read-out at that concentration, not a potency): 8%
Compound 3: the middle estimate sits 16 percentage points above what was measured; the range from low to high includes it.
By their numbers in this assay, from the lowest: compounds 1 and 3 (each within the scatter of the next); then compound 2.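

For the compounds shown here, on the group on the ester oxygen, this assay responds to a change that the earlier compounds left untouched: cyclohexyl in place of pentan-3-yl gives a number 14 percentage points lower from compound 2 to compound 3 (beyond the scatter). The ester in itself therefore does not go with the higher reading, as cyclohexyloxy in place of isopropylamino gives no change at the digits printed from compound 1 to compound 3 (within the scatter), and the gain seen in a number 14 percentage points higher from compound 1 to compound 2 (beyond the scatter) holds for the (pentan-3-yl)oxy ester but not for the cyclohexyl ester. No measurement available here bears on why the two esters differ.

As far as these compounds go, it remains open whether the reading of compound 2 at 22% belongs to the open branched chain as such or to pentan-3-yl alone, a question that cyclopentyl, hexan-3-yl or a straight pentyl chain on the same oxygen would help to settle. Also open, from the compounds shown here alone, is whether the amide and ester differ at all once the alkyl group is matched, which (pentan-3-yl)amino or cyclohexylamino on the carbonyl carbon would test directly against compound 2 and compound 3.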